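Benzylamino replaces dimethylamino on a shared fused core

The source may report more compounds than this note shows. Statements on the series, on what has been measured and on what is new or still open speak of the compounds shown alone.

Measured compounds:
compound 1 `CNc1nc(/C=C/c2ccccc2)nc2ccsc12` — > 1000000 nM (a limit)
compound 2 `COc1cc(/C=C/c2nc(N(C)C)c3sccc3n2)cc(OC)c1OC` — > 1000000 nM (a limit)

In a functional assay on L02 cells (Homo sapiens) for inhibition, read by Griess assay, with stated times of 1 h and 24 h (a higher number here means a weaker inhibitor, a lower number a stronger inhibitor), compound 1 gives only a limit, > 1000000 nM. Compound 2 likewise gives only a limit in this assay, > 1000000 nM. Both values therefore sit at the limit of > 1000000 nM in this assay, at which 2 of the 2 values shown sit, and no numbered step between measured compounds is available.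

Compound 3 `COc1cc(/C=C/c2nc(NCc3ccccc3)c3sccc3n2)cc(OC)c1OC` is not yet measured. It differs from compound 2 in one place: benzylamino in place of dimethylamino on an aromatic carbon. The rest of the structure, with its trimethoxy-bearing styryl group and the shared fused core, is unchanged.

With both measured compounds at a limit, the step from compound 2 to compound 3 is expected to be small or absent, and the estimate is written as an at least 1.2-fold lower number from compound 2 to compound 3 (0.09 log units; that floor lies within the scatter). Compound 3 is therefore expected to give about 800000 nM in this assay, within a range from 200000 nM to 3000000 nM, and most likely again only a limit.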

Compound 3, half-maximal inhibitory concentration: > 1000000 nM
Compound 3 ended at the assay's limit; the forecaster's own chance of this, stated with the estimate: 70%; at least 1.2-fold (0.09 log units) between middle value and limit.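

Among these compounds, no step from compound 2 to compound 3 can be read in this assay, because both give only a limit: the limit of > 1000000 nM in this assay, at which 3 of the 3 values shown sit. The compounds shown leave open whether benzylamino and dimethylamino differ at all on the shared core, since none gives a value inside the assay's range.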